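The source may hold more compounds than are shown below. What is called first, only, known or untested is meant among the compounds shown, and "the series" means these compounds.

Three compounds share one core and differ only in a single group on an aromatic carbon. Compound 1 `Cc1cccc(C(=O)Nc2nn[nH]n2)n1` carries a methyl there, compound 2 `O=C(Nc1nn[nH]n1)c1cccc(Br)n1` a bromo, and compound 3 `O=C(Nc1nn[nH]n1)c1ccccn1` a hydrogen. In a functional assay on the whole organism for inhibition, with Rattus norvegicus as the target, at a dose of 3 mg/kg by the oral route (a lower number here means a weaker effect, a higher number a stronger effect of the compound at the dose given), compound 1 gives 46%, compound 2 gives 38%, and compound 3 gives 29%, which is the lowest of the three numbers. The step of a number 9 percentage points lower from compound 2 to compound 3 (within the scatter) lies within the scatter, whereas the step of a number 17 percentage points lower from compound 1 to compound 3 (beyond the scatter) lies beyond it, so compound 1 is the only one that stands clearly apart from compound 3.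

Compound 4 `O=C(Nc1nn[nH]n1)c1cccc(Cl)n1` is the compound not yet measured. Its change from compound 3 is chloro in place of hydrogen on an aromatic carbon. The measured step that bears most closely on this change is a number 9 percentage points lower from compound 2 to compound 3 (within the scatter), a bromo-to-hydrogen swap that stayed within the scatter; the methyl-to-hydrogen step a number 17 percentage points lower from compound 1 to compound 3 (beyond the scatter) was larger. Because compound 2 gave 38%, a chloro in the same place is expected to behave more like the bromo than the methyl. In this assay compound 4 is therefore expected to give 37%, within a range from 25% to 50%. The expected step of a number 8 percentage points higher from compound 3 to compound 4 (within the scatter) is estimated to be small and quite possibly within the scatter.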

Compound 4, a percentage reported as inhibition, in the whole organism at one dose (the size of the read-out at that dose, not a potency): 18%
Compound 4: the middle estimate sits 19 percentage points above what was measured, and the stated range ends above it.
By their numbers in this assay, from the lowest: compound 4; then compounds 3, 2 and 1 (each within the scatter of the next, the first and the last beyond it).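

Compound 3, with its hydrogen, no longer marks the bottom of the series: in this assay, placing a chloro on this aromatic carbon, next to the ring nitrogen, gives a number 11 percentage points lower from compound 3 to compound 4 (beyond the scatter), the first group seen here to fall clearly below hydrogen. The chloro and the bromo also part ways, with a number 20 percentage points lower from compound 2 to compound 4 (beyond the scatter), so at this position one halogen cannot be taken as a stand-in for the other. For the compounds shown here, the step of a number 28 percentage points lower from compound 1 to compound 4 (beyond the scatter) is the widest gap in the set, which shows that the choice of this single group can separate compounds clearly, and that the order of the groups could not have been read from the earlier compounds alone.

Why chlorine and bromine diverge at this position remains unexplained, as nothing available here bears on the cause. A fluoro, a methoxy, an amine or a trifluoromethyl group at the same carbon would help show whether the low number belongs to the chloro alone or is shared by other groups, and each result would still describe the effect at one dose, not a potency.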